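The source may report more compounds than this note shows. Statements on the series, on what has been measured and on what is new or still open speak of the compounds shown alone.

Working notes on the series

Three compounds have been run through a functional assay on HepG2 cells (Homo sapiens) for cytotoxicity, read by MTT assay, with a stated time of 24 h (a lower number here means a stronger inhibitor, a higher number a weaker inhibitor), so far. Compound 1 `COc1cc(/C=C2\CN(C)C/C(=C\c3cccnc3)C2=O)cc(OC)c1` gives 6910 nM in this assay. Compound 3 `COc1cc(/C=C2\CN(C)C/C(=C\c3ccncc3)C2=O)cc(OC)c1` carries the same core as compound 1; in this assay compound 3 gives 9500 nM. The change between them is pyridin-4-yl in place of pyridin-3-yl on a double-bonded chain carbon bound to a double-bonded ring carbon, and the step of a 1.4-fold higher number from compound 1 to compound 3 (0.14 log units; within the scatter). Compound 2 `COc1ccc(/C=C2\CN(C)C/C(=C\c3cccnc3)C2=O)c(OC)c1OC` gives 5160 nM in this assay; the difference between the core of compound 2 and the core of compound 1 is not broken down here, and all three values sit within the scatter of one another.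

Compound 4 `COc1ccc(/C=C2\CN(C)C/C(=C\c3ccncc3)C2=O)c(OC)c1OC` has not yet been measured in this assay. It differs from compound 2 by pyridin-4-yl in place of pyridin-3-yl on a double-bonded chain carbon bound to a double-bonded ring carbon, which is the same change as that from compound 1 to compound 3. Because a 1.4-fold higher number from compound 1 to compound 3 (0.14 log units; within the scatter) stayed within the scatter, a comparable step is expected for compound 4, so a 1.4-fold higher number from compound 2 to compound 4 (0.13 log units; within the scatter) is the expected size of the move from compound 2. Compound 4 is therefore estimated at 7000 nM in this assay, with the likely span running from 3800 nM to 13000 nM.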

Compound 4, half-maximal inhibitory concentration: 3560 nM
For compound 4 the middle estimate is 2.0-fold (0.29 log units) above the measured one; measured number outside the range, below it.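

On the core of compound 2, pyridin-4-yl in place of pyridin-3-yl gives a 1.4-fold lower number from compound 2 to compound 4 (0.16 log units; within the scatter) in this assay. Set beside the same change on the core of compound 1, the two steps point in opposite directions, but they do not differ by more than two such steps can scatter: the same change on two cores in this assay, a 1.4-fold higher number (0.14 log units; within the scatter) from compound 1 to compound 3 and a 1.4-fold lower number (0.16 log units; within the scatter) from compound 2 to compound 4, 2.0-fold (0.30 log units) apart, within the scatter of two such steps. The change can therefore be carried between these two cores without a step beyond the scatter on either, but the opposite directions carry no weight, and two pairs do not show that the change is without effect on other cores or in other assays.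

The compounds shown leave open whether pyridin-2-yl, or a phenyl ring carrying an amine or a carboxylic acid, on the same double-bonded chain carbon would move the number in this assay beyond the scatter. They also leave open whether the step stays this small on a core where hydroxyl or fluorine stands in place of the methoxy groups.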